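The source may report more compounds than this note shows. Statements on the series, on what has been measured and on what is new or still open speak of the compounds shown alone.

Values so far in a functional assay on B16 cells (Mus musculus) for antiproliferative activity, with a stated time of 72 h (a higher number here means a weaker inhibitor, a lower number a stronger inhibitor), are as follows.

Compound 1 (`OC[C@H]1O[C@@H](n2cnc3c(NCc4ccc(F)c(Cl)c4)ncnc32)[C@H](O)[C@@H]1O`) gives 167000 nM as its result
Compound 2 (`OC[C@H]1O[C@@H](n2cnc3c(NCc4cc(O)cc(O)c4)ncnc32)[C@H](O)[C@@H]1O`) gives "not determined" (no result reported) as its result

Compound 2 therefore has no single number to stand on, and it offers no starting level for any comparison. The only measured level comes from compound 1 (167000 nM) in this series. Still awaiting measurement is compound 3 (`Cc1ccc(O)c(CNc2ncnc3c2ncn3[C@@H]2O[C@H](CO)[C@@H](O)[C@H]2O)c1`) on the same cells. The structural change 2-hydroxy-5-methylphenyl in place of 3,5-dihydroxyphenyl on a saturated chain carbon bound to a nitrogen on an aromatic ring puts 2-hydroxy-5-methylphenyl in place of 3,5-dihydroxyphenyl on a saturated chain carbon bound to a nitrogen on an aromatic ring, and the shared core stays as it is. Among the measured compounds shown here, the data hold no measured step for this change, and no step from compound 2 can be calculated. In this assay no shift beyond the scatter is expected relative to the one available level, that of compound 1 (167000 nM) with its neighbouring structure. The estimated value for compound 3 is 130000 nM with an expected range from 40000 nM to 350000 nM as the likely span.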

Compound 3, half-maximal inhibitory concentration: > 166000 nM
Compound 3 was reported as a limit (the forecaster's own chance of this, stated with the estimate: 25%); middle value at least 1.2-fold (0.10 log units) away from the limit.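

In this assay compound 3 gives > 166000 nM, which is a limit and not a number. Among the compounds shown here, no step can therefore be read from compound 1 to compound 3, and compound 2 has no result to compare. The compounds shown leave open whether replacing either benzyl group with 2-hydroxy-5-methylbenzyl changes the antiproliferative result at all.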